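A few compounds are considered here, and "the series" means these few. Any claim that something is new, unique, unknown or untested is made for them only; others in the source may bear on it.

In an assay for inhibition of transmembrane protease serine 4 (Homo sapiens), read by fluorescence (a higher number here means a weaker inhibitor, a lower number a stronger inhibitor), compound 1 `O=C(Nc1cc(C(F)(F)F)cc(C(F)(F)F)c1)c1cc(Br)ccc1O` gives 13000 nM. Compound 2 `COc1ccc(O)c(C(=O)Nc2cc(C(F)(F)F)cc(C(F)(F)F)c2)c1` gives 29000 nM, so compound 1 holds the lowest of the two numbers recorded; putting methoxy in place of bromo brought a 2.2-fold higher number from compound 1 to compound 2 (0.35 log units; beyond the scatter). Compound 3 `O=C(Nc1cc(C(F)(F)F)cc(C(F)(F)F)c1)c1ccc2ccccc2c1O` gives only a limit of the assay, > 100000 nM. That is the limit of > 100000 nM in this assay, at which 1 of the 3 values shown sits. Compound 4 `O=C(Nc1cc(C(F)(F)F)cc(C(F)(F)F)c1)c1cc(Cl)cnc1O` has not yet been measured; it differs from compound 1 by 5-chloro-2-hydroxypyridin-3-yl in place of 5-bromo-2-hydroxyphenyl on a carbonyl carbon. For the measured compounds named here, no measured step swaps the ring in this way; the one step known changed a single substituent and stayed modest, so for this assay a step of similar or smaller size is expected, in either direction. Compound 4 is therefore estimated at 20000 nM, between 6000 nM and 60000 nM, which means an expected step of a 1.5-fold higher number from compound 1 to compound 4 (0.19 log units; within the scatter).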

Compound 4, half-maximal inhibitory concentration: > 100000 nM
Compound 4: no number, only a limit; the forecaster's own chance of this, stated with the estimate: 10%; at least 5.0-fold (0.69 log units) between middle value and limit.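

In this assay, 5-chloro-2-hydroxypyridin-3-yl in place of 5-bromo-2-hydroxyphenyl on the carbonyl carbon gives an at least 7.6-fold higher number from compound 1 to compound 4 (0.88 log units; beyond the scatter), a larger step than the earlier substituent change, a 2.2-fold higher number from compound 1 to compound 2 (0.35 log units; beyond the scatter). So this position does not tolerate every small change equally, and changing the ring itself can cost more than changing one substituent. Compound 4 gives only a limit, not a number, and it is not alone there: the limit of > 100000 nM in this assay, at which 2 of the 4 values shown sit.

Whether the ring nitrogen or the chlorine accounts for this step stays open, and a 5-chloro-2-hydroxyphenyl group would separate the two. Going by these compounds, how an amine in place of bromo would read also stays open.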